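A few compounds are considered here, and "the series" means these few. Any claim that something is new, unique, unknown or untested is made for them only; others in the source may bear on it.

Three compounds share one core and differ in the group on the nitrogen on the aromatic ring. Compound 1 `COc1ccc(Nc2nc(Oc3cccc(NC(=O)C=C(C)C)c3)c3sccc3n2)cc1` gives 28800 nM in a functional assay on HeLa cells (Homo sapiens) for inhibition, read by MTT assay, with a stated time of 72 h; on this read-out lower numbers stand for stronger inhibition and higher numbers for weaker inhibition. Compound 2 `COc1ccc(Nc2nc(Oc3cccc(NC(=O)C=C(C)C)c3)c3sccc3n2)cn1` reaches in this assay only > 100000 nM, which is a limit of the assay and not a number. Compound 3 `CC(C)=CC(=O)Nc1cccc(Oc2nc(Nc3cccc(C#N)c3)nc3ccsc23)c1` gives 19800 nM in this assay, the lowest of the two numbers recorded, and the gap to the nearest number is a 1.5-fold lower number from compound 1 to compound 3 (0.16 log units; within the scatter). The other two moves, an at least 3.4-fold higher number from compound 1 to compound 2 (0.54 log units; beyond the scatter) and an at least 5.0-fold lower number from compound 2 to compound 3 (0.70 log units; beyond the scatter), involve a value that sits at the limit (the limit of > 100000 nM in this assay, at which 1 of the 3 values shown sits).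

Compound 4 `CCC/C=C/C(=O)Nc1cccc(Oc2nc(Nc3cccc(C#N)c3)nc3ccsc23)c1` differs from compound 3 at another place: pent-1-en-1-yl in place of 2-methylprop-1-en-1-yl on a carbonyl carbon. Among the measured compounds shown here, none of the measured steps touches the group on the carbonyl carbon; all three alter the group on the nitrogen on the aromatic ring, so they give no guide to the size or direction of this change. No step beyond the scatter is therefore expected, and compound 4 is estimated to give about 20000 nM in this assay, between 7000 nM and 60000 nM, an expected step of a 1.0-fold higher number from compound 3 to compound 4 (0.00 log units; within the scatter).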

Compound 4, half-maximal inhibitory concentration: 42100 nM
Compound 4: the middle estimate sits 2.1-fold (0.32 log units) below what was measured; low and high end bracket the measured number.
By their numbers in this assay, from the lowest: compounds 3, 1 and 4 (each within the scatter of the next, the first and the last beyond it). At a limit, above all of these: compound 2.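

In this assay, the group on the carbonyl carbon turns out not to be neutral: pent-1-en-1-yl in place of 2-methylprop-1-en-1-yl gives a 2.1-fold higher number from compound 3 to compound 4 (0.33 log units; beyond the scatter), the only step shown at this place, as all earlier steps altered the group on the nitrogen on the aromatic ring. The change is small in what is counted, since both groups hold no ring, one double bond outside aromatic rings and no hydrogen-bond donors or acceptors, while the entering group has 5 carbon against 4. Nothing shown here accounts for this step.

Going by these compounds, it remains open whether the same change would move the number in the same direction with 4-methoxyphenyl on the nitrogen, as in compound 1. Also open, on these data alone, is what a longer chain such as hept-1-en-1-yl, a saturated pentyl group or an amine on the chain would give.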